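This account rests on a few compounds, and the source may have more. Where it says the series, first, only, none or still open, it means among the compounds named here.

Measured in a functional assay on HeLa cells (Homo sapiens) for antiproliferative activity, read by MTT assay, with a stated time of 48 h; a lower number here means a stronger inhibitor, a higher number a weaker inhibitor:
- Compound 1 `COc1ccc2c(/C=C/C(=O)c3cc(OC)c(OC)c(SC)c3)c[nH]c2c1`: 131 nM
- Compound 2 `COc1ccc2c(/C=C/C(=O)c3cc(N)c(OC)c(OC)c3)c[nH]c2c1`: 155 nM

Among the measured compounds shown here, compound 2, at 155 nM, stands level with the only other measured compound, as the one available step shows: a 1.2-fold higher number from compound 1 to compound 2 (0.07 log units; within the scatter). The two cannot be ranked in this assay.

Compound 3 `COc1ccc2c(/C=C/C(=O)c3cc(N)c(OC)c(OC)c3)cn(C)c2c1` has methyl in place of hydrogen on an aromatic nitrogen. For the measured compounds named here, the measured step between compound 1 and compound 2 lies on an aromatic carbon, so it bears on this change only loosely, and no measured pair tests the nitrogen itself. The expectation therefore rests on compound 2 at 155 nM, with no step beyond the scatter and no firm direction anticipated in this assay. The expected step is a 1.4-fold lower number from compound 2 to compound 3 (0.15 log units; within the scatter). For compound 3 the estimated value is 110 nM, with an expected range of 30 nM to 450 nM.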

Compound 3, half-maximal inhibitory concentration: 356 nM
Compound 3: the middle estimate sits 3.2-fold (0.51 log units) below what was measured; measured number inside the range.
By their numbers in this assay, from the lowest: compounds 1 and 2 (each within the scatter of the next); then compound 3.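

Methyl in place of hydrogen on the aromatic nitrogen gives a 2.3-fold higher number from compound 2 to compound 3 (0.36 log units; beyond the scatter) in this assay and, though modest, this is the first step among the compounds shown that separates two of them. The earlier step, on an aromatic carbon, could not rank its pair, whereas this pair shows that the number responds to a single added carbon at this nitrogen, with the hydrogen-bearing compound giving the lower number. No available measurement accounts for this step.

The compounds shown leave open whether the step comes from losing the hydrogen or from adding the methyl, and whether an ethyl, benzyl or acetyl group on this nitrogen would move the number further. They also leave open whether the same methyl would have a comparable effect with methylsulfanyl in place of amino on the aromatic carbon.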